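Tetradecyl furan amide to isoquinoline amide: expected cytotoxicity

This account rests on a few compounds, and the source may have more. Where it says the series, first, only, none or still open, it means among the compounds named here.

Of the compounds shown here, three have been measured in a functional assay on SiHa cells (Homo sapiens) for cytotoxicity, read by MTT assay, with a stated time of 48 h; a higher number here means a weaker inhibitor, a lower number a stronger inhibitor. Compound 1 `CCCCCCCCNC(=O)[C@@H](NC(=O)c1ccco1)[C@@H](C)O` gives 124000 nM. Compound 2 `CCCCCCCCCCCCNC(=O)[C@@H](NC(=O)c1nccc2ccccc12)[C@@H](C)O` gives 56600 nM. Compound 3 `CCCCCCCCCCCCCCNC(=O)[C@@H](NC(=O)c1ccco1)[C@@H](C)O` gives 127000 nM, the highest of the three numbers; its nearest neighbour is compound 1, within the scatter, and its furthest is compound 2, beyond the scatter.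

The step under consideration leads from compound 3 to compound 4 `CCCCCCCCCCCCCCNC(=O)[C@@H](NC(=O)c1nccc2ccccc12)[C@@H](C)O`. The change is isoquinolin-1-yl in place of furan-2-yl on a carbonyl carbon; the chain on the other amide nitrogen stays as it is.

For the measured compounds named here, no measured step changes the acyl group alone. Going by the values given here, the only measured step, a 1.0-fold higher number from compound 1 to compound 3 (0.01 log units; within the scatter), shows that lengthening the chain leaves this assay unchanged. Compound 2 carries the isoquinolin-1-yl group on a shorter chain, and its number is lower than that of compound 3. Taken together, the chain length appears indifferent and the isoquinoline carries the lower number, so a moderate fall is expected, about a 2.1-fold lower number from compound 3 to compound 4 (0.33 log units; beyond the scatter), close to what compound 2 shows.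

Compound 4 is therefore estimated at 60000 nM, with a range from 25000 nM to 150000 nM.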

Compound 4, half-maximal inhibitory concentration: 21600 nM
The estimate for compound 4 lay 2.8-fold (0.44 log units) above the measured number; measured number below the stated range.
By their numbers in this assay, from the lowest: compound 4; then compound 2; then compounds 1 and 3 (each within the scatter of the next).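

For the compounds shown here, with the chain held fixed, replacing furan-2-yl with isoquinolin-1-yl on the carbonyl carbon gives a direct reading of the acyl change in this assay (a 5.9-fold lower number from compound 3 to compound 4 (0.77 log units; beyond the scatter)), which the earlier compounds could only suggest across different chains. The chain also proves not to be indifferent on the isoquinolin-1-yl amide: the ethyl extension gives a 2.6-fold lower number from compound 2 to compound 4 (0.42 log units; beyond the scatter), whereas the hexyl extension on the furan-2-yl amide gave a 1.0-fold higher number from compound 1 to compound 3 (0.01 log units; within the scatter), so among these four compounds the response to chain length differs with the acyl group, and the two changes together give compound 4 the lowest number of the pairs that can be read. Nothing on hand accounts for either step.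

The compounds shown leave open whether the number keeps falling with a longer chain on the isoquinolin-1-yl amide, and whether the furan-2-yl amides stay flat at chain lengths other than those of compound 1 and compound 3. They also cannot separate the second ring from the ring nitrogen, a question that a naphthyl or a pyridyl group on the same carbonyl carbon would address.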